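Three Close Values and One Untested Ester

The compounds below may be only part of what the source reports. "The series", "measured", "known", "first", "only" and "open" are said of these compounds alone.

Measured in a functional assay on HeLa cells (Homo sapiens) for cytotoxicity, read by MTT assay; on this read-out higher numbers stand for weaker inhibition and lower numbers for stronger inhibition:
- compound 1 `CCCC(O)CC(=O)O[C@H](CC=C(C)C)C1=CC(=O)c2c(O)ccc(O)c2C1=O`: 59300 nM
- compound 2 `COC(C)CO[C@H](CC=C(C)C)C1=CC(=O)c2c(O)ccc(O)c2C1=O`: 53400 nM
- compound 3 `CCC(CO[C@H](CC=C(C)C)C1=CC(=O)c2c(O)ccc(O)c2C1=O)OC(C)=O`: 44000 nM

Compound 3, at 44000 nM, cannot be separated from the other two compounds. The measured steps are a 1.3-fold lower number from compound 1 to compound 3 (0.13 log units; within the scatter) and a 1.2-fold lower number from compound 2 to compound 3 (0.08 log units; within the scatter), and both lie within the scatter, as does a 1.1-fold lower number from compound 1 to compound 2 (0.05 log units; within the scatter). The next compound, compound 4 `CC(C)=CC[C@@H](OC(=O)C1CCCCO1)C1=CC(=O)c2c(O)ccc(O)c2C1=O`, changes the same place: (oxan-2-yl)carbonyl in place of 2-acetoxybutyl on an oxygen on a saturated carbon. In words, (oxan-2-yl)carbonyl stands in place of 2-acetoxybutyl on an oxygen on a saturated carbon.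

The closest evidence is a 1.3-fold lower number from compound 1 to compound 3 (0.13 log units; within the scatter), which exchanges (2-hydroxypentyl)carbonyl for 2-acetoxybutyl at that oxygen. The other two steps also show that changing this substituent has so far left this assay almost unmoved. Within the data shown here, none of the measured compounds carries the new ring, however, so the range must stay wide. The expected change is no step beyond the scatter, and the estimate is a 1.0-fold higher number from compound 3 to compound 4 (0.02 log units; within the scatter). Compound 4 is expected at about 46000 nM, within an estimated range of 20000 nM to 90000 nM.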

Compound 4, half-maximal inhibitory concentration: > 100000 nM
Compound 4 was reported as a limit; the forecaster's own chance of this, stated with the estimate: 10%; at least 2.1-fold (0.33 log units) between middle value and limit.
By their numbers in this assay, from the lowest: compounds 3, 2 and 1 (each within the scatter of the next). At a limit, above all of these: compound 4.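

In this assay compound 4 is reported only as a limit, > 100000 nM, and it stands alone there: the limit of > 100000 nM in this assay, at which 1 of the 4 values shown sits. Among these compounds, at this oxygen, where the earlier exchanges stayed within the scatter, the change from 2-acetoxybutyl to (oxan-2-yl)carbonyl gives the first step beyond it, an at least 2.2-fold higher number from compound 3 to compound 4 (0.35 log units; beyond the scatter), although the two groups match in heavy atoms and hydrogen-bond acceptors and the entering group adds one six-membered non-aromatic ring. The floors of the other two steps, an at least 1.8-fold higher number from compound 2 to compound 4 (0.27 log units; that floor lies within the scatter) and an at least 1.6-fold higher number from compound 1 to compound 4 (0.22 log units; that floor lies within the scatter), lie within the scatter, so these two pairs are not separated on their own.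

On these data alone, how far compound 4 lies past its limit remains unknown. The compounds shown also leave open whether a cyclohexyl or a piperidin-2-yl ring on the same carbonyl carbon would behave like oxan-2-yl.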